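Methoxy to fluoro on the aryl ketone ring

A few compounds are considered here, and "the series" means these few. Any claim that something is new, unique, unknown or untested is made for them only; others in the source may bear on it.

Three analogues share one core. Compound 1 `COc1ccccc1C(=O)/C=C/CCc1ccccc1` gives 1720 nM in a functional assay on HEK293 cells for antagonist activity at G-protein coupled receptor 52 (Homo sapiens), read by cAMP accumulation, with stated times of 15 min and 30 min (on this read-out higher numbers stand for weaker inhibition and lower numbers for stronger inhibition), compound 2 `COc1cccc(C(=O)/C=C/CCc2ccccc2)c1` gives 1490 nM, and compound 3 `O=C(/C=C/CCc1ccccc1)c1ccccc1F` gives 1760 nM; all three sit within the scatter of one another. From compound 1 to compound 3 the change is fluoro in place of methoxy on an aromatic carbon, and it made a 1.0-fold higher number from compound 1 to compound 3 (0.01 log units; within the scatter). Compound 2 and compound 1 have the same atoms joined differently; the difference between the two cores is not broken down here. Compound 4 `O=C(/C=C/CCc1ccccc1)c1cccc(F)c1` is not yet measured; from compound 2 it differs by fluoro in place of methoxy on an aromatic carbon. This is the same kind of change as that from compound 1 to compound 3, not the same: there the place is ortho to a large group, here meta to a large group. The expected step is a 1.0-fold higher number from compound 2 to compound 4 (0.00 log units; within the scatter), beside a 1.0-fold higher number from compound 1 to compound 3 (0.01 log units; within the scatter). Because compound 3 gives 1760 nM after the earlier change, compound 4 is estimated at 1500 nM, between 750 nM and 3000 nM.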

Compound 4, half-maximal inhibitory concentration: 2370 nM
Compound 4: the middle estimate sits 1.6-fold (0.20 log units) below what was measured, and the stated range covers the measured number.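

In this assay, fluoro in place of methoxy, meta to a large group, gives a 1.6-fold higher number from compound 2 to compound 4 (0.20 log units; within the scatter). The change carries from one core to the other with no difference that can be told apart from the noise: the same change on two cores in this assay, a 1.0-fold higher number (0.01 log units; within the scatter) from compound 1 to compound 3 and a 1.6-fold higher number (0.20 log units; within the scatter) from compound 2 to compound 4, 1.6-fold (0.19 log units) apart, within the scatter of two such steps. This shows that the exchange leaves the number within the scatter on both cores; it does not show that the step is independent of the core, as the two steps also differ in place on the ring and the two effects cannot be separated.

Still open, as far as these compounds go, is whether an amine, a carboxylic acid or a nitrile on that ring would behave like methoxy and fluoro. Also open, from the compounds shown here alone, is whether the exchange holds on a core with a longer chain.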